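Ether variation on the aryl oxygen: inhibition at one concentration

The source may hold more compounds than are shown below. What is called first, only, known or untested is meant among the compounds shown, and "the series" means these compounds.

Measured compounds:
compound 1 `O=C1NCc2c1c1c(c3c2c2ccccc2n3CCO)CCc2cc(OC3CCCCC3)ccc2-1`: 35%
compound 2 `O=C1NCc2c1c1c(c3[nH]c4ccccc4c23)CCc2cc(O)ccc2-1`: 9%
compound 3 `O=C1NCc2c1c1c(c3c2c2ccccc2n3CCO)CCc2cc(OCC3CC3)ccc2-1`: 30%

In an assay on isolated protein for inhibition of mitogen-activated protein kinase kinase kinase 9 (Homo sapiens), tested at 1 uM (a higher number here means more inhibition at the concentration tested (going by the name of the read-out), a lower number less inhibition), compound 3 stands second highest of the three numbers. Its nearest neighbour is compound 1, and the step of a number 5 percentage points lower from compound 1 to compound 3 (within the scatter) lies within the scatter. Within the data shown here, compound 2, which carries a free hydroxyl on the aromatic ring and lacks the hydroxyethyl on the ring nitrogen, gives a number well below compound 3; no single-place step connects them.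

Compound 4 `O=C1NCc2c1c1c(c3c2c2ccccc2n3CCO)CCc2cc(OCCOCc3ccccc3)ccc2-1` is not yet measured. It differs from compound 3 in one place: (benzyloxy)methyl in place of cyclopropyl on a saturated chain carbon bound to an oxygen on an aromatic ring. Among the measured compounds shown here, the only measured step on the same oxygen, a number 5 percentage points lower from compound 1 to compound 3 (within the scatter), is within the scatter, so exchange of the group on that oxygen has so far moved this assay little. For the measured compounds named here, no measured step covers a chain bearing an added ether oxygen, so the expectation rests on that one step alone.

For compound 4 a step within the scatter is expected, a number 2 percentage points lower from compound 3 to compound 4 (within the scatter). The estimate for compound 4 in this assay is 28%, with a range from 12% to 45%.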

Compound 4, a percentage reported as inhibition, at one concentration (the size of the read-out at that concentration, not a potency): 9%
Compound 4: the middle estimate sits 19 percentage points above what was measured; measured number below the stated range.
By their numbers in this assay, from the lowest: compounds 2 and 4 (each within the scatter of the next); then compounds 3 and 1 (each within the scatter of the next).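

In this assay, the group on the oxygen on the aromatic ring proves less free to change than the earlier pair suggested: a number 21 percentage points lower from compound 3 to compound 4 (beyond the scatter) and a number 26 percentage points lower from compound 1 to compound 4 (beyond the scatter) are both larger than the scatter. Among the three groups compared on this oxygen, cyclohexyl and cyclopropylmethyl remain within the scatter of each other, while 2-(benzyloxy)ethyl is set apart from both. The data at hand offer no measurement that accounts for this loss.

In compound 4, the longer chain, the added ether oxygen and the six-membered aromatic ring all enter together, so their separate contributions remain unresolved. A 2-methoxyethyl group, which keeps the ether oxygen without the aromatic ring, or a 3-phenylpropyl group, which keeps the aromatic ring without the ether oxygen, would help to separate them.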